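Ester, acid and amide variants at the seven-membered ring

This account rests on a few compounds, and the source may have more. Where it says the series, first, only, none or still open, it means among the compounds named here.

Measured so far in an assay on cells for displacement of a labelled ligand from Orexin/Hypocretin receptor type 1 (Homo sapiens), read by scintillation counting, with stated times of 10 min and 90 min, tested at 10 uM; on this read-out higher numbers stand for more inhibition at the one concentration tested (going by the name of the read-out) and lower numbers for less inhibition:
compound 1 `COC(=O)c1ccc2ccc(C(=O)c3ccccc3)c-2cc1` gives 7.2%
compound 2 `O=C(O)c1ccc2ccc(C(=O)c3ccccc3)c-2cc1` gives 11%
compound 3 `NC(=O)c1ccc2ccc(C(=O)c3ccccc3)c-2cc1` gives 13.6%

Compound 3 carries the highest of the three numbers, but every step between the three compounds lies within the scatter: a number 3.8 percentage points higher from compound 1 to compound 2 (within the scatter), a number 6.4 percentage points higher from compound 1 to compound 3 (within the scatter) and a number 2.6 percentage points higher from compound 2 to compound 3 (within the scatter). The three therefore count as one cluster of low inhibition, with no ordering that can be trusted.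

Compound 4 `COC(=O)Cc1ccc2ccc(C(=O)c3ccccc3)c-2cc1` is the next variant at the same position. The change from compound 3 is (methoxycarbonyl)methyl in place of carbamoyl on an aromatic carbon. Compound 1 already carries a methoxycarbonyl group there, so compound 4 differs from it only by the methylene link.

Going by the values given here, the steps that bear on the change are the three above, each swapping the group on the same aromatic carbon of the seven-membered ring and each staying within the scatter. On that basis no step beyond the scatter is expected for this assay either; the estimated step is a number 4.6 percentage points lower from compound 3 to compound 4 (within the scatter), in no trusted direction. Compound 4 is expected to give 9% in this assay, with a range of 0% to 22%.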

Compound 4, a percentage reported as inhibition, at one concentration (the size of the read-out at that concentration, not a potency): -37.7%
For compound 4 the middle estimate is 46.7 percentage points above the measured one; the whole stated range lies above it.
By their numbers in this assay, from the lowest: compound 4; then compounds 1, 2 and 3 (each within the scatter of the next).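

In this assay the three earlier groups on this aromatic carbon of the seven-membered ring stayed within the scatter of one another, whereas (methoxycarbonyl)methyl is the first group shown to separate from them, with all three new steps beyond the scatter and large (a number 51.3 percentage points lower from compound 3 to compound 4 (beyond the scatter); a number 48.7 percentage points lower from compound 2 to compound 4 (beyond the scatter); a number 44.9 percentage points lower from compound 1 to compound 4 (beyond the scatter)). Going by these compounds alone, the last of these is the most direct comparison, since the methoxycarbonyl group is present on both sides and the change amounts to the methylene link, so a methoxycarbonyl group alone does not account for the low number of compound 4 (-37.7%), which is also the only negative value. No measurement shown here gives a reason for this step.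

The compounds shown leave open whether the methylene link gives the same large step with other groups on it, such as a carboxylic acid, a primary amide or an amine in place of the methyl ester. They also leave open what a longer chain, such as a two-carbon link ending in the same methoxycarbonyl group, would give in this assay at this aromatic carbon.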